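This account rests on a few compounds, and the source may have more. Where it says the series, first, only, none or still open, it means among the compounds named here.

Series of three ureas measured in an ADME assay on the whole organism with Oryza sativa as the target, tested at 0.1 uM; a lower number here means a stronger effect, a higher number a weaker effect of the compound at the concentration tested. Compound 1 `CCc1cccc(NC(=O)N[C@H](C)c2ccccc2)c1` gives 97%. Compound 2 `CCc1cccc(NC(=O)N[C@@H](C)c2ccccc2)c1` gives 100%. Compound 3 `C[C@@H](NC(=O)Nc1ccc(Br)cc1)c1ccccc1` gives 100%. Going by the values given here, the only single-point step among them runs a number 3 percentage points higher from compound 1 to compound 2 (within the scatter); it is set apart from the substituent changes by the fact that compounds 1 and 2 differ only in the configuration as drawn, since the two compounds share every atom and bond. On the numbers shown, compound 2 stands level with compound 3 at the digits reported and sits together with it at the top of the three, with compound 1 below it only within the scatter.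

Compound 4 `C[C@H](NC(=O)Nc1cccc(I)c1)c1ccccc1` is not yet measured. It arises from compound 2 by iodo in place of ethyl on an aromatic carbon. Among the compounds with values here, no measured step replaces one group by another on the aromatic ring, so no step bears directly on this change; the only measured step, from compound 1 to compound 2, was a change of configuration alone and stayed within the scatter. Compound 3, carrying a halogen on its ring, gives 100%, and all three measured values lie within the scatter of one another. The step is therefore expected to be a number 3 percentage points lower from compound 2 to compound 4 (within the scatter), none beyond the scatter. Compound 4 is expected to give about 97%, with a range from 85% to 100%.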

Compound 4, a percentage reported as activity, at one concentration (the size of the read-out at that concentration, not a potency): 98%
Compound 4: the middle estimate sits 1 percentage points below what was measured; low and high end bracket the measured number.
By their numbers in this assay, from the lowest: compounds 1, 4, 2 and 3 (each within the scatter of the next).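

In this assay, going by these compounds alone, iodo in place of ethyl on an aromatic carbon, meta to a large group, gives a number 2 percentage points lower from compound 2 to compound 4 (within the scatter), the first measured step that replaces one group by another on the aromatic ring rather than changing configuration alone. At this place and at the one concentration tested, the read-out therefore does not separate ethyl from iodo, and this exchange of groups stays as small as the change of configuration did. Nothing on hand bears on why this step stays so small.

Still open, from the compounds shown here alone, is whether a different kind of group at this place, such as an amine, a carboxylic acid or a longer alkyl chain, would take the read-out beyond the scatter. Also open, going by these compounds, is whether iodo and ethyl would still read alike at a higher concentration.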